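A Bromo Swap at the Limit of the Assay

The source may report more compounds than this note shows. Statements on the series, on what has been measured and on what is new or still open speak of the compounds shown alone.

Within the data shown here, compound 1 `Oc1cccc(/C=N/n2cnnc2)c1` and compound 2 `Oc1ccc(/C=N/n2cnnc2)cc1` are the two hydroxy compounds measured so far in a functional assay on PC-3 cells (Homo sapiens) for cytotoxicity; on this read-out lower numbers stand for stronger inhibition and higher numbers for weaker inhibition. Compound 1 reads > 30000 nM, which is a limit and not a number. Compound 2 reads > 30000 nM, which is likewise only a limit. Compound 2 therefore has no exact value of its own, and the pair stands together at the limit of > 30000 nM in this assay, at which 2 of the 2 values shown sit.

The next compound is compound 3 `Brc1ccc(/C=N/n2cnnc2)cc1`, with bromo in place of hydroxy on an aromatic carbon, para to a group of 7 heavy atoms: bromo in place of hydroxy on an aromatic carbon. Among the measured compounds shown here, no measured pair yet shows what a single change does in this assay, so the expectation rests on the limit and on this one change. The limit of compound 2, > 30000 nM, means that only a shift toward stronger inhibition could appear as a number. The reading may well stay at the limit, and any shift is expected to be modest. The expected step is an at least 1.5-fold lower number from compound 2 to compound 3 (0.17 log units; that floor lies within the scatter). For compound 3 the estimate is 20000 nM, with an expected range from 6000 nM to 60000 nM.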

Compound 3, half-maximal inhibitory concentration: > 30000 nM
Compound 3 ended at the assay's limit; the forecaster's own chance of this, stated with the estimate: 60%; middle value at least 1.5-fold (0.17 log units) away from the limit.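

Among these compounds, compound 3 reads > 30000 nM in this assay, which is a limit and not a number, so no step from compound 2 to compound 3 can be read. The three compounds stand together: the limit of > 30000 nM in this assay, at which 3 of the 3 values shown sit.

The compounds shown leave open how bromo and hydroxy compare at this place, and what any single change to the shared core does to a measurable value.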